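A few compounds are considered here, and "the series" means these few. Any claim that something is new, unique, unknown or untested is made for them only; others in the source may bear on it.

Two compounds have so far been measured in an ADME assay on C8166 cells (Homo sapiens) for cytotoxicity, read by colorimetric assay and MTT assay; a lower number here means that less compound is tolerated, a higher number that more compound is tolerated:

compound 1 `Cc1cccc(C(=O)c2c(OCC(=O)Nc3ccc(S(N)(=O)=O)cc3C)ccc3ccccc23)c1`, giving 40400 nM
compound 2 `Cc1cccc(C(=O)c2c(OCC(=O)Nc3ccc(S(N)(=O)=O)cc3C)ccc3cc(Br)ccc23)c1`, giving 6800 nM

For the measured compounds named here, compound 2 stands at the lowest of these two numbers; its nearest neighbour is compound 1, and the single measured step between them is a 5.9-fold lower number from compound 1 to compound 2 (0.77 log units; beyond the scatter), a bromo in place of hydrogen on an aromatic carbon. Compound 3 `Cc1cccc(C(=O)c2c(OCC(=O)Nc3ccc(S(N)(=O)=O)cc3C)ccc3cc(C#N)ccc23)c1` differs from compound 2 by cyano in place of bromo on an aromatic carbon. Going by the values given here, no measured step exchanges bromo for cyano, so the one step on record bears only indirectly: it shows that a substituent at this carbon can move the number in this assay by a modest amount, but not what cyano does there. A modest shift is therefore expected in this assay, with a lean toward a somewhat higher number and no firm direction. Compound 3 is estimated at 11000 nM, within 4000 nM to 30000 nM, which corresponds to an expected step of a 1.6-fold higher number from compound 2 to compound 3 (0.21 log units; within the scatter).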

Compound 3, half-maximal cytotoxic concentration: 15200 nM
Compound 3: middle estimate off by 1.4-fold (0.14 log units), on the low side, within the range that was stated.
By their numbers in this assay, from the lowest: compound 2; then compound 3; then compound 1.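

In this assay, cyano in place of bromo on this aromatic carbon gives a 2.2-fold higher number from compound 2 to compound 3 (0.35 log units; beyond the scatter), so the number depends on which group sits here and not only on whether a substituent is present. Cyano in place of hydrogen still gives a 2.7-fold lower number from compound 1 to compound 3 (0.42 log units; beyond the scatter), which puts compound 3 between the other two and leaves both substituted compounds on the same side of compound 1. No evidence is at hand to explain these shifts.

The compounds shown leave open how other groups on this carbon, such as an amine, a carboxylic acid or a longer chain, would fall relative to bromo and cyano. They also leave open whether bromo and cyano would keep this order at another carbon of the shared core.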